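Compound 3 to compound 4: a saturated chain

The source may hold more compounds than are shown below. What is called first, only, known or untested is meant among the compounds shown, and "the series" means these compounds.

In a functional assay on MDA-MB-231 cells (Homo sapiens) for antiproliferative activity, read by MTT assay (on this read-out lower numbers stand for stronger inhibition and higher numbers for weaker inhibition), compound 1 (`CCCC/C=C\CCCCCCCCCc1cc(=O)c2c(O)cc(OCOC)cc2o1`) gives > 87000 nM as a limit, not a number. Compound 2 (`CCCC/C=C\CCCCCCCCCc1cc(=O)c2c(O)c(C)c(OCOC)c(C)c2o1`) gives > 87000 nM as a limit too. Compound 3 (`CCCC/C=C\CCCCCCCCCc1cc(=O)c2c(O)cc(OCOC)c(C)c2o1`) gives > 87000 nM as a limit as well. Every measured compound therefore stands at the limit of > 87000 nM in this assay, at which 3 of the 3 values shown sit, and none can be ranked. Compound 4 (`CCCCCCCCCCCCCCCc1cc(=O)c2c(O)cc(OCOC)c(C)c2o1`) differs from compound 3 by hexyl in place of hex-1-en-1-yl on a saturated chain carbon, nine bonds along the chain from an aromatic carbon with hexyl in place of hex-1-en-1-yl on a saturated chain carbon. The measured changes swap methyl and hydrogen on an aromatic carbon and give no size: a step that the two limits leave unreadable from compound 1 to compound 3 and a step that the two limits leave unreadable from compound 2 to compound 3 are all there is. With compound 3 at > 87000 nM and nothing measured for this chain change, the estimated step that the limit leaves unreadable from compound 3 to compound 4 in this assay is expected to stay within the scatter, with no direction. Compound 4 is estimated at 90000 nM with 35000 nM to 200000 nM as its expected range.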

Compound 4, half-maximal inhibitory concentration: > 87000 nM
Compound 4 gave a limit, no number (the forecaster's own chance of this, stated with the estimate: 75%); the middle value does not contradict the limit.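

Compound 3 and compound 4 both give only a limit, not a number, so no step between them can be read: the limit of > 87000 nM in this assay, at which 4 of the 4 values shown sit.

The compounds shown leave open whether hexyl in place of hex-1-en-1-yl changes the activity at all.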